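A few compounds are considered here, and "the series" means these few. Any claim that something is new, unique, unknown or untested is made for them only; others in the source may bear on it.

Measured compounds:
compound 1 `C=C1CC[C@@H]2[C@](C)(CO)[C@H](O)CC[C@@]2(C)[C@@H]1CCC1C(=O)OC[C@H]1O`: 34.2%
compound 2 `C=C1CC[C@@H]2[C@](C)(CO)[C@H](O)CC[C@@]2(C)/C1=C/C=C1\C=COC1=O`: "not active" (no number reported)
compound 3 `C=C1CC[C@@H]2[C@](C)(CO)[C@H](O)CC[C@@]2(C)[C@@H]1/C=C/C1=C/C(=C/C=C(/C)CCC=C(C)C)OC1=O`: "not active" (no number reported)

In an assay on isolated protein for inhibition of Maltase-glucoamylase (Homo sapiens), tested at 100 uM (a higher number here means more inhibition at the concentration tested (going by the name of the read-out), a lower number less inhibition), compound 1 gives 34.2%. Compound 2 gives "not active" (no number reported) in this assay. Compound 3 gives "not active" (no number reported) in this assay; no single number exists for compound 3, it shares this outcome with compound 2, and it cannot be placed against compound 1 by a figure. Compound 4 `C=C1CC[C@@H]2[C@](C)(CO)[C@H](O)CC[C@@]2(C)[C@@H]1/C=C/C1=C/C(=C/c2cccc(Br)c2)OC1=O` differs from compound 3 by 3-bromophenyl in place of 2,6-dimethylhepta-1,5-dien-1-yl on a double-bonded chain carbon bound to a double-bonded ring carbon. For the measured compounds named here, no step between measured compounds is available, and the size of this step in this assay cannot be read from any pair. The expectation is for no movement beyond the scatter, with compound 4 remaining weak. For compound 4 the expected inhibition in this assay is 15%, within a range from 0% to 40%.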

Compound 4, a percentage reported as inhibition, at one concentration (the size of the read-out at that concentration, not a potency): 16.7%
Beside the measured number, compound 4's estimate is 1.7 percentage points below it; low and high end bracket the measured number.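

For the compounds shown here, compound 3 carries no number, only "not active", so no step from it to compound 4 can be read. The compounds shown leave open how much the 3-bromophenyl group itself changes inhibition. No evidence here bears on this result.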